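This account rests on a few compounds, and the source may have more. Where it says the series, first, only, none or still open, it means among the compounds named here.

Measured compounds:
- Compound 1 `O=C1O[C@H]([C@@H](O)Cn2cc(-c3cc(C(F)(F)F)cc(C(F)(F)F)c3)nn2)C(OCc2ccccc2)=C1OCc1ccccc1` gives 45900 nM in a functional assay on MCF7 cells (Homo sapiens) for antiproliferative activity, read by MTT assay, with a stated time of 72 h; on this read-out lower numbers stand for stronger inhibition and higher numbers for weaker inhibition
- Compound 2 `COc1ccc(-c2cn(C/C=C3\OC(=O)C(OCc4ccccc4)=C3OCc3ccccc3)nn2)cc1` gives 39100 nM
- Compound 3 `O=C1O[C@H]([C@@H](O)Cn2cc(CNS(=O)(=O)c3ccc(F)cc3)nn2)C(OCc2ccccc2)=C1OCc1ccccc1` gives 26800 nM

All three numbers sit close together at the weak end of what this assay reports. Compound 3 has the lowest number of the three, but its gap to compound 2 and its gap to compound 1 both lie within the scatter of repeated measurements, so no ordering among them can be claimed.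

Compound 4 `O=C1O[C@H]([C@@H](O)Cn2ccnn2)C(OCc2ccccc2)=C1OCc1ccccc1` keeps the shared core of compound 3 and differs from it in one place: hydrogen in place of (((4-fluorophenyl)sulfonyl)amino)methyl on an aromatic carbon. Among the measured compounds shown here, no pair of measured compounds here differs in a single place, so there is no measured step to lean on; the three compounds carry quite different groups on the five-membered ring and still give numbers that cannot be told apart.

On that basis, the step is expected to be small, most likely a modest move toward a higher number or none beyond the scatter. The estimate for compound 4 in this assay is 55000 nM, with a range from 18000 nM to 170000 nM, which amounts to an expected step of a 2.1-fold higher number from compound 3 to compound 4 (0.31 log units; beyond the scatter).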

Compound 4, half-maximal inhibitory concentration: > 100000 nM
Compound 4: no number, only a limit (the forecaster's own chance of this, stated with the estimate: 30%); at least 1.8-fold (0.25 log units) between middle value and limit.
By their numbers in this assay, from the lowest: compounds 3, 2 and 1 (each within the scatter of the next). At a limit, above all of these: compound 4.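

In this assay compound 4, which carries only hydrogen on this aromatic carbon of the five-membered ring, gives > 100000 nM, and this is a limit of the assay, not a number. Among the compounds shown here, putting hydrogen in place of the (((4-fluorophenyl)sulfonyl)amino)methyl group gives an at least 3.7-fold higher number from compound 3 to compound 4 (0.57 log units; beyond the scatter), the first measured step at this position, and it shows that losing this group costs activity that can be detected in this assay, even though the larger groups seen so far gave numbers that could not be told apart. As far as these compounds go, the full size of the step remains unknown because compound 4 reaches only a limit: the limit of > 100000 nM in this assay, at which 1 of the 4 values shown sits.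

The compounds shown leave open which part of the lost group matters, since a plain aminomethyl group or a methyl on this aromatic carbon would show whether a short substituent is enough or whether the 4-fluorophenyl ring and the sulfonyl unit are needed. They also leave open whether any group at this position, such as a carboxylic acid or a longer chain ending in an amine, can bring the number well down from the weak range seen here.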